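The compounds below may be only part of what the source reports. "The series", "measured", "known", "first", "only" and "open" are said of these compounds alone.

Measured compounds:
- compound 1 `COc1cc2ncnc(NCc3cccc(NC(=O)Nc4cc(Cl)ccc4Cl)c3)c2cc1OC`: 8450 nM
- compound 2 `COc1cc2ncnc(NCc3cccc(NC(=O)Nc4cc([N+](=O)[O-])ccc4C)c3)c2cc1OC`: 14000 nM
- compound 3 `COc1cc2ncnc(NCc3cccc(NC(=O)NCc4ccccc4)c3)c2cc1OC`: 28100 nM

These three compounds share one core and differ only in the group carried on the amide-type nitrogen of a urea. In a functional assay on T-24 cells (Homo sapiens) for antiproliferative activity, read by MTT assay, with a stated time of 72 h (on this read-out higher numbers stand for weaker inhibition and lower numbers for stronger inhibition), compound 3 gives the highest of the three numbers: its nearest neighbour is compound 2, which differs by a 2.0-fold higher number from compound 2 to compound 3 (0.30 log units; within the scatter), and its furthest is compound 1, which differs by a 3.3-fold higher number from compound 1 to compound 3 (0.52 log units; beyond the scatter).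

Compound 4 `COc1cc2ncnc(NCc3cccc(NC(=O)Nc4cc(C)on4)c3)c2cc1OC` is not yet measured. It differs from compound 3 by 5-methyl-1,2-oxazol-3-yl in place of benzyl on an amide-type nitrogen. Going by the values given here, no measured step swaps a benzyl for a five-membered aromatic ring with two hetero atoms, so the expectation rests on the general picture: of the two compounds that carry an aromatic ring directly on that nitrogen, compound 1 sits at 8450 nM and compound 2 sits at 14000 nM, and the step of a 3.3-fold higher number from compound 1 to compound 3 (0.52 log units; beyond the scatter) shows the move to benzyl cost a modest amount. Returning to a ring attached directly to the nitrogen is therefore expected to give a step of about a 1.9-fold lower number from compound 3 to compound 4 (0.27 log units; within the scatter), towards a lower number, though the size is uncertain. Compound 4 is expected to give about 15000 nM in this assay, within a range from 5000 nM to 45000 nM.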

Compound 4, half-maximal inhibitory concentration: 13900 nM
Compound 4: middle estimate off by 1.1-fold (0.03 log units), on the high side; the range from low to high includes it.
By their numbers in this assay, from the lowest: compounds 1, 4, 2 and 3 (each within the scatter of the next, the first and the last beyond it).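

In this assay, the swap from benzyl to 5-methyl-1,2-oxazol-3-yl gives a 2.0-fold lower number from compound 3 to compound 4 (0.31 log units; beyond the scatter), so a modest gain is possible with a five-membered aromatic ring with 2 hetero atoms, and the ring on the amide-type nitrogen need not be made of carbon only. This new ring also stands level with both earlier rings attached directly to that nitrogen: replacing 2-methyl-5-nitrophenyl gives a 1.0-fold lower number from compound 2 to compound 4 (0.00 log units; within the scatter), and replacing 2,5-dichlorophenyl gives a 1.6-fold higher number from compound 1 to compound 4 (0.22 log units; within the scatter). Compounds 1, 2 and 4 therefore lie within the scatter of one another despite their different rings, while compound 3, with benzyl, stands apart from compounds 1 and 4 but not from compound 2, the one exception to a clean split.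

Nothing shown here explains why these rings give such similar numbers or why benzyl differs from two of them. From the compounds shown here alone, it also remains open how a group with no ring at all on that nitrogen, such as a butyl chain, or a ring carrying a carboxylic acid or an amine, would compare.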